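The compounds below may be only part of what the source reports. "The series", "measured", "known", "first", "only" and "open" are said of these compounds alone.

Of the compounds shown here, three sharing one core have been measured in a functional assay on UACC-62 cells (Homo sapiens) for cytotoxicity, read by sulforhodamine B assay, with a stated time of 48 h, tested at 1 uM; a lower number here means a stronger effect, a higher number a weaker effect of the compound at the concentration tested. Compound 1, `COc1cc(-c2cc(/C=C/C(=O)c3ccc(N)cc3)[nH]n2)cc(OC)c1OC`, carries a 4-aminophenyl on its carbonyl carbon; compound 2 is `COc1ccc(-c2cc(/C=C/C(=O)c3ccc(OC)c(OC)c3)[nH]n2)cc1` and compound 3 is `COc1cc(-c2cc(/C=C/C(=O)c3ccc(Cl)c(Cl)c3)[nH]n2)cc(OC)c1OC`. In this assay compound 1 gives 86%. Compound 2 gives 85%, and compound 3 gives 96%. Among the measured compounds shown here, compound 1 thus stands second highest of the three numbers, but all three lie within the usual scatter of one another, so none can be called stronger or weaker; the single measured step, a number 10 percentage points higher from compound 1 to compound 3 (within the scatter), comes from 3,4-dichlorophenyl in place of 4-aminophenyl on a carbonyl carbon.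

Compound 4, `COc1ccc(-c2cc(/C=C/C(=O)c3ccc(N)cc3)[nH]n2)cc1OC`, is not yet measured. It differs from compound 1 by hydrogen in place of methoxy on an aromatic carbon. For the measured compounds named here, no measured step touches this part of the molecule; the one measured step sits on the carbonyl side and stays within the scatter. Compound 2 also has fewer methoxy groups on that ring, but its carbonyl side differs too, so its value and that of compound 1 show only that both stand close. Every number here is high, meaning a weak effect at the tested concentration. Compound 4 is therefore expected to give 86%, with a range from 72% to 98%. The expected step is no change at the digits printed from compound 1 to compound 4 (within the scatter), none beyond the scatter.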

Compound 4, a percentage reported as activity, at one concentration (the size of the read-out at that concentration, not a potency): 95%
Compound 4: middle estimate off by 9 percentage points, on the low side, within the range that was stated.
By their numbers in this assay, from the lowest: compounds 2, 1, 4 and 3 (each within the scatter of the next, the first and the last beyond it).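

Hydrogen in place of methoxy on an aromatic carbon is the first measured change on this side of the molecule, and in this assay it gives a number 9 percentage points higher from compound 1 to compound 4 (within the scatter). This methoxy group, ortho to a methoxy group and meta to a large group, can therefore be exchanged for hydrogen without separating compound 4 from compound 1 at the tested concentration, and the same holds for the change on the carbonyl side, a number 10 percentage points higher from compound 1 to compound 3 (within the scatter). No separate measurement on these compounds speaks to what underlies this reading.

Open, as far as these compounds go, is whether a different group on this aromatic carbon, such as a hydroxyl group, a fluorine atom or an ethoxy group, would give a number beyond the scatter of compound 1. Also open, from the compounds shown here alone, is whether hydrogen in place of this methoxy would read the same with another group on the carbonyl side, such as the 3,4-dichlorophenyl of compound 3, and whether compound 1 and compound 4 would stay together at other concentrations.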